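Swapping Fluorines for Methyls on a Urea Nitrogen

A few compounds are considered here, and "the series" means these few. Any claim that something is new, unique, unknown or untested is made for them only; others in the source may bear on it.

Measured compounds:
- compound 1, `O=C(Nc1c(F)cc(F)cc1F)N(Cc1ccc(-c2cccs2)cc1)C1CCCCCC1` — > 1 mg/kg
- compound 2, `CN(C)c1ccc(CN(Cc2cccc(-c3cc[nH]n3)c2)C(=O)Nc2c(F)cc(F)cc2F)cc1` — < 0.32 mg/kg
- compound 3, `CSc1cc(C)nc(SC)c1NC(=O)N(Cc1ccccc1)Cc1ccc(-c2cc[nH]n2)cc1` — < 0.32 mg/kg

The three compounds above were tested in a functional assay on a cell-free system (plasma) with sterol O-acyltransferase, Soat (Rattus norvegicus) as the target; on this read-out higher numbers stand for an effect only at larger amounts of compound and lower numbers for an effect already at smaller amounts. In this assay compound 1 gives > 1 mg/kg, which is a limit of the assay and not a number. Compound 2 gives < 0.32 mg/kg, again a limit rather than a number. Compound 3 gives < 0.32 mg/kg, also a limit. So compound 1 stands at one limit, (the limit of > 1 mg/kg in this assay, at which 1 of the 3 values shown sits), while the other two sit at a different limit, (the limit of < 0.32 mg/kg in this assay, at which 2 of the 3 values shown sit). Between compound 1 and either of the others no step can be counted, only that their values lie at different ends of the measured window.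

The new compound 4, `Cc1cc(C)c(NC(=O)N(Cc2ccc(-c3cccs3)cc2)C2CCCCCC2)c(C)c1`, differs from compound 1 in one place: 2,4,6-trimethylphenyl in place of 2,4,6-trifluorophenyl on an amide-type nitrogen. For the measured compounds named here, no pair of measured compounds shows this change, so its size is unknown here. For this assay a step of moderate size is expected, likely toward an effect at smaller amounts, though a change within the scatter cannot be ruled out. The expected step from compound 1 to compound 4 is an at least 1.4-fold lower number from compound 1 to compound 4 (0.15 log units; that floor lies within the scatter). For compound 4 the estimate is 0.7 mg/kg, with a range from 0.2 mg/kg to 3 mg/kg.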

Compound 4, dose for half-maximal effect: 0.28 mg/kg
Compound 4: the middle estimate sits 2.5-fold (0.40 log units) above what was measured; low and high end bracket the measured number.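

Replacing 2,4,6-trifluorophenyl with 2,4,6-trimethylphenyl on the amide-type nitrogen gives, in this assay, an at least 3.5-fold lower number from compound 1 to compound 4 (0.55 log units; beyond the scatter). For the compounds shown here, the earlier compounds differ from one another in more than one place, so no step can be read among them, and this pair is the first to isolate the ring on the urea while the rest of the core of compound 1 stays the same. The size of this step is only a floor, since compound 1 holds a limit and not a number: the limit of > 1 mg/kg in this assay, at which 1 of the 4 values shown sits.

The compounds shown do not tell why the methyl groups give the lower number, or whether all of them are needed, since no ring here carries only one or two methyl groups. Also open, as far as these compounds go, is how a ring carrying chlorine atoms or methoxy groups would read at this position, and whether the same swap would have a similar effect on the core of compound 2, which carries the same 2,4,6-trifluorophenyl group.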